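From Morpholin-4-yl to Piperazin-1-yl on a Carbonyl

This account rests on a few compounds, and the source may have more. Where it says the series, first, only, none or still open, it means among the compounds named here.

Compound 1 `Cc1c(C(=O)N2CCOCC2)oc2ccc(Nc3ncnc4ccc(Cl)nc34)cc12`: 1800 nM
Compound 2 `CN(C)C(=O)c1cccc(C#Cc2ccccc2Nc2ncnc3ccc(Cl)nc23)c1`: > 10000 nM (a limit, not a number)

In an assay on isolated protein for inhibition of MAP kinase-interacting serine/threonine-protein kinase 2 (Homo sapiens), read by HTRF, in the presence of a further agent that is not named here (on this read-out lower numbers stand for stronger inhibition and higher numbers for weaker inhibition), compound 1 gives 1800 nM, the only true number among the measurements shown. For compound 2 this assay reports only a limit, > 10000 nM, as noted in the limit of > 10000 nM in this assay, at which 1 of the 2 values shown sits. Compound 3 `Cc1c(C(=O)N2CCNCC2)oc2ccc(Nc3ncnc4ccc(Cl)nc34)cc12` differs from compound 1 in a single place: piperazin-1-yl in place of morpholin-4-yl on a carbonyl carbon. For the measured compounds named here, no measured pair shows this change, so its effect is unknown. The step is expected to stay within the usual scatter, which means an estimated step of no change at the digits printed from compound 1 to compound 3 (within the scatter). Compound 3 is therefore expected at about 1800 nM, with a range from 600 nM to 5500 nM.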

Compound 3, half-maximal inhibitory concentration: 1900 nM
Beside the measured number, compound 3's estimate is 1.1-fold (0.02 log units) below it; the range from low to high includes it.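

Replacing morpholin-4-yl with piperazin-1-yl on a carbonyl carbon gives a 1.1-fold higher number from compound 1 to compound 3 (0.02 log units; within the scatter) in this assay for this single swap. For the compounds shown here, this is the first measured step at this position, and it shows that a ring carrying a hydrogen-bond donor in place of the ring oxygen reads the same here as morpholin-4-yl. Nothing shown explains this outcome.

One pair cannot show how far this holds at this position. Going by these compounds, whether a 4-methylpiperazin-1-yl group or an open-chain amine on the same carbonyl carbon would read alike remains open.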